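A few compounds are considered here, and "the series" means these few. Any claim that something is new, unique, unknown or untested is made for them only; others in the source may bear on it.

In a functional assay on MDA-MB-231 cells (Homo sapiens) for antiproliferative activity, read by MTT assay, with a stated time of 24 h (a lower number here means a stronger inhibitor, a higher number a weaker inhibitor), compound 1 `CCCCc1oc2ccccc2c1C(=O)c1ccc(OCC(N)=O)cc1` gives > 50000 nM, which is a limit of the assay and not a number. Compound 2 `CCCCc1oc2ccccc2c1C(=O)c1ccc(OCC(=O)N2CCCC2)cc1` gives > 50000 nM, also a limit. The measured record therefore amounts to the limit of > 50000 nM in this assay, at which 2 of the 2 values shown sit. That leaves a step that the two limits leave unreadable from compound 1 to compound 2. Compound 3 `CCCCc1oc2ccccc2c1C(=O)c1ccc(OCC(=O)N2CCCCC2)cc1` differs from compound 2 by piperidin-1-yl in place of pyrrolidin-1-yl on a carbonyl carbon, with piperidin-1-yl in place of pyrrolidin-1-yl on a carbonyl carbon. Among the compounds with values here, the one measured step offers no size to carry over, so no change beyond the scatter is expected in this assay, and no direction. The estimated change is a number no higher from compound 2 to compound 3 (the limit leaves the size open). The expected value for compound 3 is 50000 nM, within an estimated range from 20000 nM to 100000 nM.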

Compound 3, half-maximal inhibitory concentration: > 50000 nM
Compound 3: only a limit was reported (the forecaster's own chance of this, stated with the estimate: 80%); the middle value lies on the limit itself.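

Compound 1, compound 2 and compound 3 all stop at a limit of the assay, so no step among them can be read: the limit of > 50000 nM in this assay, at which 3 of the 3 values shown sit.

How strongly any of these compounds inhibits in this assay stays open.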